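Methyl for hydrogen on the core chain of compound 1

The compounds below may be only part of what the source reports. "The series", "measured", "known", "first", "only" and "open" are said of these compounds alone.

Measured so far:
compound 1 `CCC(CC)Nc1nc(OC)c(-c2ccc(Cl)cc2Cl)nc1C`: 0.283 h
compound 2 `CCc1nc(-c2ccc(Cl)cc2Cl)c(CC)nc1SC(C)CC`: 0.0683 h

In an in vitro ADME assay on microsomes (Rattus norvegicus) for metabolic stability (on this read-out lower numbers stand for a shorter-lived compound and higher numbers for a longer-lived compound), compound 1 gives 0.283 h, the higher of the two numbers obtained. Compound 2 gives 0.0683 h, a lower number beyond the usual scatter. The two compounds differ in several places at once, so the two values only show that compound 1 is the longer-lived of the pair; nothing more is drawn from them.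

Compound 3 `CCc1nc(-c2ccc(Cl)cc2Cl)c(OC)nc1NC(CC)CC` is the next member awaiting a number in this assay. It differs from compound 1 by methyl in place of hydrogen on a saturated chain carbon bound to an aromatic carbon, which, read one bond further out, amounts to methyl to ethyl. Among the compounds with values here, no measured pair carries this kind of single change, so the size of the step rests on expectation alone. The step of a 1.2-fold lower number from compound 1 to compound 3 (0.09 log units; within the scatter) is expected to be small, within the scatter, with a slight lean toward a lower number rather than a higher one. Compound 3 is expected to give about 0.23 h, within 0.09 h to 0.6 h.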

Compound 3, half-life: 0.183 h
Estimate against measurement, compound 3: 1.3-fold (0.10 log units) above, within the range that was stated.
By their numbers in this assay, from the lowest: compound 2; then compounds 3 and 1 (each within the scatter of the next).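

Methyl in place of hydrogen on a saturated chain carbon bound to an aromatic carbon, which reads as methyl to ethyl, gives in this assay the first single-place step of the series: a 1.5-fold lower number from compound 1 to compound 3 (0.19 log units; within the scatter). At this place, therefore, the extra carbon leaves the half-life within the scatter, and methyl and ethyl are not separated by this read-out. Nothing at hand bears on why this step is as small as it is.

Still open, from the compounds shown here alone, is whether a longer chain such as propyl or butyl at this place, or a chain ending in a hydroxyl group, an amine or a carboxylic acid, would give a step beyond the scatter in this assay. Equally open, going by these compounds, is whether the step between methyl and ethyl stays this small when the other groups on the shared core are changed, for example when the methoxy group of compound 1 is replaced by an ethoxy group or the branched amine chain by a cyclopentylamine.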